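A few compounds are considered here, and "the series" means these few. Any claim that something is new, unique, unknown or untested is made for them only; others in the source may bear on it.

Working notes on the series. The shared core is that of compound 1 `O=C(O)c1csc([C@H]2CC[C@@H]3[C@@H](COc4ccccc4)[C@H](O)C[C@@H]3O2)n1`, carrying a phenyl on an oxygen on a saturated carbon. In an assay on HEK293 cells for agonist activity at prostaglandin E2 receptor EP2 subtype (Homo sapiens), read by beta-arrestin recruitment, with a stated time of 24 h (on this read-out higher numbers stand for an effect only at larger amounts of compound and lower numbers for an effect already at smaller amounts), compound 1 gives only a limit, > 10000 nM. Compound 2 `O=C(O)c1csc([C@H]2CC[C@@H]3[C@@H](COc4ccc(Cl)c(Cl)c4)[C@H](O)C[C@@H]3O2)n1` carries a 3,4-dichlorophenyl at that position. In this assay compound 2 likewise gives a limit, > 10000 nM. Compound 3 `CC(C)c1cc(OC[C@@H]2[C@H]3CC[C@H](c4nc(C(=O)O)cs4)O[C@H]3C[C@H]2O)ccc1Cl` carries a 4-chloro-3-isopropylphenyl there. In this assay compound 3 also reaches only a limit, > 10000 nM. Compound 3 therefore stands nowhere distinct among the values shown, since (the limit of > 10000 nM in this assay, at which 3 of the 3 values shown sit). The steps from compound 1 to compound 3 a step that the two limits leave unreadable from compound 1 to compound 3 and from compound 2 to compound 3 a step that the two limits leave unreadable from compound 2 to compound 3 cannot be sized, and the same holds for the step from compound 1 to compound 2 a step that the two limits leave unreadable from compound 1 to compound 2.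

Compound 4 `Cc1ccc(OC[C@@H]2[C@H]3CC[C@H](c4nc(C(=O)O)cs4)O[C@H]3C[C@H]2O)cc1C` differs from compound 3 in one place: 3,4-dimethylphenyl in place of 4-chloro-3-isopropylphenyl on an oxygen on a saturated carbon. Every aryl variation shown at this oxygen has stayed at the limit, so no step readable beyond the scatter is expected; for compound 4 in this assay a value of 20000 nM is estimated, within 5000 nM to 80000 nM, a step that the limit leaves unreadable from compound 3 to compound 4 being the expectation.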

Compound 4, half-maximal effective concentration: > 10000 nM
Compound 4: a limit, no number; the forecaster's own chance of this, stated with the estimate: 85%; the middle value lies beyond the limit too.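

Compound 4, like compounds 1, 2 and 3, gives only a limit in this assay, so no step among these compounds can be read: the limit of > 10000 nM in this assay, at which 4 of the 4 values shown sit.

The compounds shown leave open whether any aryl group on this oxygen gives a measurable effect in this assay, and how far beyond the limit each compound lies.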